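From azetidin-1-yl to piperidin-1-yl on a carbonyl carbon

This account rests on a few compounds, and the source may have more. Where it says the series, first, only, none or still open, it means among the compounds named here.

Measured in a physicochemical assay for solubility, read by HPLC, with a stated time of 24 h; a higher number here means a more soluble compound, a lower number a less soluble compound (three compounds)
Compound 1 `O=C(c1ccccc1)c1cccc(/C=c2\[nH]c(=O)/c(=C/c3ccccn3)[nH]c2=O)c1` gives < 0.1 ug/mL (a limit)
Compound 2 `CC(C)(C)c1[nH]cnc1/C=c1\[nH]c(=O)/c(=C/c2cccc(C(=O)N3CCCCC3)c2)[nH]c1=O` gives < 0.1 ug/mL (a limit)
Compound 3 `O=C(c1cccc(/C=c2\[nH]c(=O)/c(=C/c3ccccn3)[nH]c2=O)c1)N1CCC1` gives 0.662 ug/mL (the only number)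

Compound 3 alone gives a number, the others standing at the limit of < 0.1 ug/mL in this assay, at which 2 of the 3 values shown sit. Compound 4 `O=C(c1cccc(/C=c2\[nH]c(=O)/c(=C/c3ccccn3)[nH]c2=O)c1)N1CCCCC1` differs from it as follows: piperidin-1-yl in place of azetidin-1-yl on a carbonyl carbon. Among the measured compounds shown here, the one measured step bearing on this is an at least 6.6-fold higher number from compound 1 to compound 3 (0.82 log units; beyond the scatter), which lay beyond the scatter and put azetidin-1-yl in place of phenyl on a carbonyl carbon. Compound 2 also carries piperidin-1-yl on a carbonyl carbon, and its < 0.1 ug/mL is a limit. A lower number is therefore expected, an estimated 2.6-fold lower number from compound 3 to compound 4 (0.42 log units; beyond the scatter) in this assay. For compound 4 the estimate is 0.25 ug/mL, with an expected range of 0.1 ug/mL to 0.7 ug/mL.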

Compound 4, solubility: < 0.1 ug/mL
Compound 4 gave a limit, no number (the forecaster's own chance of this, stated with the estimate: 30%); at least 2.5-fold (0.39 log units) between middle value and limit.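

On this carbonyl carbon, piperidin-1-yl in place of azetidin-1-yl gives an at least 6.6-fold lower number from compound 3 to compound 4 (0.82 log units; beyond the scatter) in this assay, so the carbonyl-bound nitrogen ring alone does not carry the higher value seen with compound 3. Compound 4 gives a limit, not a number: the limit of < 0.1 ug/mL in this assay, at which 3 of the 4 values shown sit. The steps to compound 4 from compound 1 and from compound 2 cannot be read, since both ends are limits.

The compounds shown leave open whether pyrrolidin-1-yl or morpholin-4-yl on this carbonyl carbon would give a number. They also leave open what a hydroxyl or an amine on the azetidine ring would do.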